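A few compounds are considered here, and "the series" means these few. Any claim that something is new, unique, unknown or untested is made for them only; others in the source may bear on it.

In a physicochemical assay for lipophilicity, using the shake flask method, at pH 7.4 (on this read-out higher numbers stand for higher lipophilicity and lower numbers for lower lipophilicity), the measured compounds stand as follows:
compound 1 `Cn1ccc2ncnc(N[C@H]3CC[C@H](N(C)C)CC3)c21` gives -0.8
compound 2 `CN(C)[C@H]1CC[C@H](Nc2ncnc3cc[nH]c23)CC1` gives -0.3

Compound 2 holds the higher of the two numbers at -0.3 in this short series. Next to it comes compound 1 at -0.8 on the lower side, and the gap lies beyond the scatter.

Compound 3 `CN(C)[C@H]1CC[C@H](Nc2ncnc3ccn(C4CCOCC4)c23)CC1` is not yet measured. It carries oxan-4-yl in place of hydrogen on an aromatic nitrogen of a five-membered aromatic ring with 1 nitrogen, part of a fused or bridged system of two rings. The counted difference is oxan-4-yl in place of hydrogen on an aromatic nitrogen for this change.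

Going by the values given here, only one measured step bears on it. The step of a number 0.50 log units higher from compound 1 to compound 2 (beyond the scatter) is modest and swaps hydrogen for methyl on an aromatic nitrogen. Read in reverse, it links methyl on that nitrogen to the lower number. Oxan-4-yl is a much larger group than methyl, so this single step is a weak guide to size or direction. The expected step is a number 0.20 log units higher from compound 2 to compound 3 (within the scatter) and no shift beyond the scatter is anticipated. Compound 3 is estimated at -0.1 in this assay with an expected range from -0.7 to 0.5 for now.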

Compound 3, distribution coefficient: -0.6
For compound 3 the middle estimate is 0.50 log units above the measured one, within the range that was stated.
By their numbers in this assay, from the lowest: compounds 1, 3 and 2 (each within the scatter of the next, the first and the last beyond it).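

In this assay, oxan-4-yl on an aromatic nitrogen of a five-membered aromatic ring with 1 nitrogen gives a number 0.30 log units lower from compound 2 to compound 3 (within the scatter), so a substituent of 6 heavy atoms carrying one six-membered non-aromatic ring is tolerated here with no shift beyond the scatter from the unsubstituted nitrogen. Against methyl on the same nitrogen, the exchange gives a number 0.20 log units higher from compound 1 to compound 3 (within the scatter), which means that compound 3 is separated from neither neighbour, although a number 0.50 log units higher from compound 1 to compound 2 (beyond the scatter) had shown the only step beyond the scatter in the series, and the number therefore does not follow the heavy-atom count of the group across these three compounds. No measurement at hand accounts for these numbers.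

The compounds shown leave open whether cyclohexyl, the all-carbon ring matching oxan-4-yl, would read like compound 3, and hence what part the ring oxygen plays in this result. As far as these compounds go, it also remains open whether a carboxylic acid, an amine or a longer alkyl chain on this nitrogen would move the number beyond the scatter.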